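Amino for sulfanyl at the remaining site of compound 1

The source may hold more compounds than are shown below. What is called first, only, known or untested is meant among the compounds shown, and "the series" means these compounds.

Compound 1 `Sc1nc(S)c2cc(Sc3ccc4ccccc4c3)ccc2n1`: 5.05
Compound 2 `Nc1nc(S)c2cc(Sc3ccc4ccccc4c3)ccc2n1`: 6.64
Compound 3 `Cc1c(NC(=O)COc2ccc3ccccc3c2)ccc2nc(N)nc(N)c12`: 7.82

In an assay for inhibition of Dihydrofolate reductase (Homo sapiens) (a lower number here means a less potent compound, a higher number a more potent compound, by a factor of ten per unit of this negative logarithm), compound 1 stands lowest of the three numbers; compound 2 is nearest and compound 3 furthest, both differences beyond the scatter. Within the data shown here, only one measured step bears on the change considered here: a number 1.59 log units higher from compound 1 to compound 2 (beyond the scatter), a large rise, which also exchanged a sulfanyl for an amino on the shared core. Compound 4 `Nc1nc(S)nc2ccc(Sc3ccc4ccccc4c3)cc12` makes the same exchange at the sulfanyl that compound 2 keeps: amino in place of sulfanyl on an aromatic carbon. Among the measured compounds shown here, a rise beyond the scatter in this assay is therefore expected, though its size is uncertain because a number 1.59 log units higher from compound 1 to compound 2 (beyond the scatter) concerns a different site on the core and no pair measures this one. For compound 4 a value of 6.3 is estimated, within 5.4 to 7.2. This corresponds to an expected step of a number 1.25 log units higher from compound 1 to compound 4 (beyond the scatter).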

Compound 4, logarithm of the reciprocal of the active concentration, log(1/C): 5.52
Estimate against measurement, compound 4: 0.78 log units above; the measured number falls inside the stated range.
By their numbers in this assay, from the lowest: compound 1; then compound 4; then compound 2; then compound 3.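

In this assay, amino in place of sulfanyl at this position still gives a rise beyond the scatter, but only a modest one (a number 0.47 log units higher from compound 1 to compound 4 (beyond the scatter)). The same exchange at the other sulfanyl site gives a large rise (a number 1.59 log units higher from compound 1 to compound 2 (beyond the scatter)), so the size of the gain depends on the site. Nothing available explains this difference between the two sites.

On these data alone, whether amino at both sites on the shared core would add to these gains remains open. So does whether a methylamino or hydroxyl group at this position would match amino.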